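Swapping the heterocycle on a furanone side chain

The source may hold more compounds than are shown below. What is called first, only, known or untested is meant among the compounds shown, and "the series" means these compounds.

Measured so far:
compound 1 `Nc1ncn(CCC2(N)OC(=O)C(OCc3ccccc3)=C2OCc2ccccc2)c(=O)n1` — > 100000 nM
compound 2 `O=C1O/C(=C\Cn2ncc(=O)[nH]c2=O)C(OCc2ccccc2)=C1OCc1ccccc1` — 20400 nM

In a functional assay on MIA PaCa-2 cells (Homo sapiens) for inhibition, read by MTT assay, with a stated time of 72 h (on this read-out lower numbers stand for stronger inhibition and higher numbers for weaker inhibition), compound 1 `Nc1ncn(CCC2(N)OC(=O)C(OCc3ccccc3)=C2OCc2ccccc2)c(=O)n1` is reported only as a limit of the assay, > 100000 nM, not as a number. Going by the values given here, compound 2 `O=C1O/C(=C\Cn2ncc(=O)[nH]c2=O)C(OCc2ccccc2)=C1OCc1ccccc1` gives 20400 nM in this assay, the only number among the values shown. The other value shown, that of compound 1, is a limit (the limit of > 100000 nM in this assay, at which 1 of the 2 values shown sits). Among the compounds with values here, the two compounds differ in more than one place, so the pair shows no single step that can be followed.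

Compound 3 `Nc1ncn(C/C=C2\OC(=O)C(OCc3ccccc3)=C2OCc2ccccc2)c(=O)n1` is the next case. It differs from compound 2 by a group of 8 heavy atoms (3 carbon, 4 nitrogen, 1 oxygen; one six-membered aromatic ring with 3 hetero atoms) in place of a group of 8 heavy atoms (3 carbon, 3 nitrogen, 2 oxygen; one six-membered aromatic ring with 3 hetero atoms), on a saturated chain carbon bound to a double-bonded chain carbon. Within the data shown here, no measured step between two compounds isolates this change, so its effect is unknown. The expectation for compound 3 is therefore a step of no clear size beyond the scatter, with the possibility that this assay reports only a limit again. On that basis compound 3 is estimated at 30000 nM in this assay, within a range from 8000 nM to 120000 nM, which corresponds to an expected step of a 1.5-fold higher number from compound 2 to compound 3 (0.17 log units; within the scatter).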

Compound 3, half-maximal inhibitory concentration: 920 nM
Beside the measured number, compound 3's estimate is 33-fold (1.51 log units) above it, and the stated range ends above it.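

Going by these compounds alone, the exchange on a saturated chain carbon bound to a double-bonded chain carbon is the first single change that can be followed, and in this assay it gives a 22-fold lower number from compound 2 to compound 3 (1.35 log units; beyond the scatter). This shows that inhibition in these cells responds strongly to the identity of the heterocycle at this place, even though the leaving and entering groups have the same number of heavy atoms and the same kind of six-membered aromatic ring with 3 hetero atoms, and differ in their split of nitrogen and oxygen and in their counts of double bonds outside aromatic rings and hydrogen-bond acceptors. Nothing measured here accounts for the size of this step.

A single exchange cannot show which of these differences carries the step, or whether the shared core would tolerate other groups at this place. Going by these compounds, it also remains open how the activity would change if the heterocycle gave way to a simple amine or a carboxylic acid, or if it were carried on a longer chain.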